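A few compounds are considered here, and "the series" means these few. Any claim that something is new, unique, unknown or untested is made for them only; others in the source may bear on it.

Measured compounds:

Compound 1, `N=c1c(=O)[nH]nc2n1CCN2c1cccc(Cl)c1`, gives 50% in a functional assay on A549 cells (Homo sapiens) for antiproliferative activity, with a stated time of 72 h, tested at 50 ug/mL; a higher number here means a stronger effect of the compound at the concentration tested, a lower number a weaker effect.
Compound 2, `N=c1c(=O)[nH]nc2n1CCN2c1ccccc1Cl`, gives 16% in this assay.

Both compounds share one core and differ only in where a chloro group sits on the six-membered aromatic ring of carbon only. Compound 2 stands at the lower of the two numbers; its nearest neighbour is compound 1, whose number is higher by more than the usual scatter, so the two values are clearly apart.

The next compound, compound 3, `N=c1c(=O)[nH]nc2n1CCN2c1ccccc1`, has not yet been tested in this assay. Compared with compound 2 it shows one change: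

hydrogen in place of chloro on an aromatic carbon

Going by the values given here, no pair of measured compounds shows this exact change, so its size has to be guessed. The two measured values only show that moving the chloro group changed the number a great deal; removing it altogether could land anywhere between them. Compound 3 is therefore expected to give a step of a number 14 percentage points higher from compound 2 to compound 3 (beyond the scatter), a modest rise that may still fall within the scatter. The estimate for compound 3 is 30%, with a range from 5% to 60%.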

Compound 3, a percentage reported as inhibition, at one concentration (the size of the read-out at that concentration, not a potency): 38%
Estimate against measurement, compound 3: 8 percentage points below; the measured number falls inside the stated range.
By their numbers in this assay, from the lowest: compound 2; then compound 3; then compound 1.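

Compound 3, which carries only hydrogen on the aromatic ring, provides the reference that the two chloro compounds lacked. In this assay, putting hydrogen in place of chloro on the aromatic carbon ortho to a large group gives a number 22 percentage points higher from compound 2 to compound 3 (beyond the scatter), whereas the same exchange at the place the chloro group holds in the other chloro compound gives a number 12 percentage points lower from compound 1 to compound 3 (beyond the scatter). The same change therefore moves the number in opposite directions: relative to hydrogen, chloro lowers the read-out at one place and raises it at the other, so its effect here cannot be described without saying where it sits, and nothing available explains this difference.

Chloro is the only group shown on this ring, so it remains open whether a fluoro, methyl, methoxy or amine group at these same places would shift the number in the same directions. These read-outs also come from a single concentration, so they leave open how the three compounds would compare across a range of concentrations.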